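Chloro to methoxy on a shared core: three compounds, one estimate

The compounds below may be only part of what the source reports. "The series", "measured", "known", "first", "only" and "open" are said of these compounds alone.

Three compounds have been measured in a functional assay on HT-1080 cells (Homo sapiens) for cytotoxicity, read by MTT assay, with a stated time of 72 h; on this read-out lower numbers stand for stronger inhibition and higher numbers for weaker inhibition:

Compound 1, `COc1ccc(/C=C2\CCC/C(=C\c3ccc(Cl)cc3)C2=O)cc1OC`: 4800 nM
Compound 2, `COc1ccc(/C=C2\CCC/C(=C\c3ccc(OC)c(OC)c3)C2=O)cc1`: 7200 nM
Compound 3, `COc1ccc(/C=C2\CCC/C(=C\c3ccc(O)c(Cl)c3)C2=O)cc1OC`: 7600 nM

Compound 1 and compound 2 differ in one place: methoxy in place of chloro on an aromatic carbon. This gave a 1.5-fold higher number from compound 1 to compound 2 (0.18 log units; within the scatter). Compound 3 stands apart from compound 1 by a change in the other aryl group, (3-chloro-4-hydroxyphenyl in place of 4-chlorophenyl on a double-bonded chain carbon bound to a double-bonded ring carbon), and a 1.6-fold higher number from compound 1 to compound 3 (0.20 log units; within the scatter). Between compound 2 and compound 3 there is a 1.1-fold higher number from compound 2 to compound 3 (0.02 log units; within the scatter). All three numbers thus sit within the usual scatter of one another.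

Compound 4, `COc1cc(/C=C2\CCC/C(=C\c3ccc(OC)c(OC)c3)C2=O)ccc1O`, is not yet measured. It differs from compound 3 by methoxy in place of chloro on an aromatic carbon. This is the same kind of change as that from compound 1 to compound 2, not the same: there the new methoxy sat para to a large group, here it sits ortho to a hydroxy group and meta to a large group. The step for compound 4 is expected to be small, a 1.3-fold higher number from compound 3 to compound 4 (0.10 log units; within the scatter). That rests on compound 1 and compound 2, whose step was a 1.5-fold higher number from compound 1 to compound 2 (0.18 log units; within the scatter). Compound 4 is therefore estimated at 9500 nM in this assay, between 4500 nM and 20000 nM.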

Compound 4, half-maximal inhibitory concentration: 4600 nM
The estimate for compound 4 lay 2.1-fold (0.31 log units) above the measured number; measured number inside the range.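

Putting methoxy in place of chloro on the core of compound 3 gave a 1.7-fold lower number from compound 3 to compound 4 (0.22 log units; within the scatter) in this assay, and the two other steps to compound 4 are just as small: a 1.6-fold lower number from compound 2 to compound 4 (0.19 log units; within the scatter) and a 1.0-fold lower number from compound 1 to compound 4 (0.02 log units; within the scatter). The same change pointed in opposite directions on the two cores, yet this gap is no real difference: the same change on two cores in this assay, a 1.5-fold higher number (0.18 log units; within the scatter) from compound 1 to compound 2 and a 1.7-fold lower number (0.22 log units; within the scatter) from compound 3 to compound 4, 2.5-fold (0.39 log units) apart, within the scatter of two such steps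

So in this small set, the change from chloro to methoxy gave no step beyond the scatter on either core. That does not prove that the change behaves identically on both cores, since two small steps from a single pair each cannot settle this either way.

The aryl groups shown carry only chloro, methoxy and hydroxy groups, so it remains open whether an amine or a carboxylic acid in the same place would give a step beyond the scatter. As far as these compounds go, it is also open whether the result would hold on other cells.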